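Shifting the acid one carbon out from the aryl ring

This account rests on a few compounds, and the source may have more. Where it says the series, first, only, none or still open, it means among the compounds named here.

Compound 1 `O=C(O)c1ccc(C=C2CCN(C(=O)C(C3CCCCC3)C3CCCCC3)CC2)cc1`: 60 nM
Compound 2 `O=C(O)c1ccc(C=C2CCN(C(=O)C(c3ccccc3)c3ccccc3)CC2)c(F)c1`: 410 nM

Of the compounds shown here, two have been measured in an assay on isolated protein for inhibition of 3-oxo-5-alpha-steroid 4-dehydrogenase 2 (Homo sapiens); on this read-out lower numbers stand for stronger inhibition and higher numbers for weaker inhibition. Compound 1 gives 60 nM, the lower of the two numbers, and compound 2 gives 410 nM; the gap between these two values lies beyond the usual scatter, so compound 1 stands as the stronger inhibitor of the pair. Within the data shown here, compound 2 also differs from compound 1 in more than one place, so no single step between them can be read.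

Compound 3 `O=C(O)Cc1ccc(C=C2CCN(C(=O)C(C3CCCCC3)C3CCCCC3)CC2)cc1` has not been measured. It differs from compound 1 in one place: carboxymethyl in place of carboxy on an aromatic carbon. Among the measured compounds shown here, no measured pair shows this change. Its effect can only be guessed. The expectation is a modest move toward weaker inhibition, a step of a 2.5-fold higher number from compound 1 to compound 3 (0.40 log units; beyond the scatter), though a result within the scatter would not surprise. Compound 3 is therefore estimated at 150 nM, with a likely range from 40 nM to 600 nM.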

Compound 3, half-maximal inhibitory concentration: 6 nM
Compound 3: middle estimate off by 25-fold (1.40 log units), on the high side; the whole stated range lies above it.
By their numbers in this assay, from the lowest: compound 3; then compound 1; then compound 2.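

Within this assay, lengthening 4-carboxyphenyl to 4-(carboxymethyl)phenyl gives a 10-fold lower number from compound 1 to compound 3 (1.00 log units; beyond the scatter), a step well beyond the usual scatter. This shows that the aromatic carbon para to a large group is sensitive to exactly where the acid sits: one extra carbon, with the counts of hydrogen-bond donors and acceptors unchanged, clearly strengthens inhibition in this pair. Nothing measured here explains why the extra carbon has this effect.

On these data alone, whether a longer chain such as carboxyethyl would strengthen inhibition further, or whether a primary amide could stand in for the acid, remains open. Also open, as far as these compounds go, is whether carboxymethyl would give a similar step on the core of compound 2.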